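Swapping pyridin-3-yl for 1-methylpiperidin-4-yl on compound 1

The compounds below may be only part of what the source reports. "The series", "measured", "known", "first", "only" and "open" are said of these compounds alone.

Measured in a physicochemical assay for solubility, at pH 7; on this read-out higher numbers stand for higher solubility and lower numbers for lower solubility
- compound 1 (`CC(C)(C)C(=O)N1Cc2c(NC(=O)c3cccnc3)n[nH]c2C1(C)C`) gives 207000 nM
- compound 2 (`CN1CCC(C(=O)N2Cc3c(NC(=O)c4ccco4)n[nH]c3C2(C)C)CC1`) gives > 225000 nM as a limit of the assay

Among the measured compounds shown here, compound 1 at 207000 nM holds the only actual number so far. Compound 2 reads > 225000 nM and that is a limit of the assay, not a number.

Compound 3 (`CN1CCC(C(=O)Nc2n[nH]c3c2CN(C(=O)C(C)(C)C)C3(C)C)CC1`) is still unmeasured. It carries 1-methylpiperidin-4-yl in place of pyridin-3-yl on a carbonyl carbon and otherwise matches compound 1. For the measured compounds named here, compound 2 also holds 1-methylpiperidin-4-yl on a carbonyl carbon, but it differs from compound 1 elsewhere too, so no single-place step between measured compounds is available.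

With compound 1 at 207000 nM as the only numerical anchor, only a small change is expected. The expected 1.1-fold higher number from compound 1 to compound 3 (0.03 log units; within the scatter) stays within the usual scatter of this assay with no direction claimed. Compound 3 may also come back as a limit of the assay. For compound 3 the estimate is 220000 nM with 130000 nM to 250000 nM as the expected range.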

Compound 3, solubility: > 225000 nM
Compound 3 ended at the assay's limit; the forecaster's own chance of this, stated with the estimate: 55%; at least 1.0-fold (0.00 log units) between middle value and limit.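

In this assay compound 3 gives > 225000 nM, which is a limit of the assay and not a number. Among the compounds shown here, this position on a carbonyl carbon whose other neighbours are amide-type nitrogen now has its first single-place reading, for 1-methylpiperidin-4-yl in place of pyridin-3-yl (an at least 1.0-fold higher number from compound 1 to compound 3 (0.03 log units; that floor lies within the scatter)), and that floor says only that a non-aromatic ring can stand here with the reading still at the limit. The step has a floor and no measured size because one of its two ends is a limit, so neither its true size nor anything finer about this change can be taken from it: the limit of > 225000 nM in this assay, at which 2 of the 3 values shown sit.

Still open, on these data alone, is whether any group at this place moves the reading clearly away from compound 1, for example a carboxylic acid, a primary amine or a longer alkyl chain in place of 1-methylpiperidin-4-yl. Also open, as far as these compounds go, is how large the step from pyridin-3-yl really is, since a read-out that stops at a limit cannot separate compound 3 from anything else that reaches it.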